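Amide to Ester, and One More Chain Carbon

The source may report more compounds than this note shows. Statements on the series, on what has been measured and on what is new or still open speak of the compounds shown alone.

Three compounds have been tested in a functional assay on KB cells (Homo sapiens) for cytotoxicity, read by resazurin assay, with a stated time of 3 days; a lower number here means a stronger inhibitor, a higher number a weaker inhibitor:

compound 1 `CCCCCCC(=O)NCC(C)(C)CC1=C(O)C(=O)c2ccccc2C1=O` gives 28200 nM
compound 2 `CCCCCCCC(=O)NCC(C)(C)CC1=C(O)C(=O)c2ccccc2C1=O` gives 24600 nM
compound 3 `CCCCCCC(=O)OCC(C)(C)CC1=C(O)C(=O)c2ccccc2C1=O` gives 14400 nM

Compound 4 `CCCCCCCC(=O)OCC(C)(C)CC1=C(O)C(=O)c2ccccc2C1=O` has not yet been measured. It differs from compound 3 by methyl in place of hydrogen on a saturated chain carbon, six bonds along the chain from a carbonyl carbon. The same change is made between two measured compounds: from compound 1 to compound 2 it gave a 1.1-fold lower number from compound 1 to compound 2 (0.06 log units; within the scatter), so lengthening the chain by one carbon did nothing that rises above the ordinary scatter of the assay. The core on which the change is made is not identical in the two pairs: compound 3 differs from compound 1 by (hexylcarbonyl)oxy in place of (hexylcarbonyl)amino on a saturated chain carbon, three bonds along the chain from a double-bonded ring carbon, and that change gave a 2.0-fold lower number from compound 1 to compound 3 (0.29 log units; within the scatter), again within scatter. Since the place of the added carbon is described in the same words for both pairs, the change from compound 3 to compound 4 is the same change.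

The expectation for compound 4 therefore rests on compound 1 and compound 2, whose step was a 1.1-fold lower number from compound 1 to compound 2 (0.06 log units; within the scatter). Compound 4 is expected to show a step of about a 1.1-fold lower number from compound 3 to compound 4 (0.04 log units; within the scatter) in this assay. Compound 4 is estimated at 13000 nM, with a likely range from 6500 nM to 26000 nM.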

Compound 4, half-maximal inhibitory concentration: 38300 nM
Beside the measured number, compound 4's estimate is 2.9-fold (0.47 log units) below it; measured number above the stated range.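

On the ester core, adding one carbon to the chain gave a 2.7-fold higher number from compound 3 to compound 4 (0.42 log units; beyond the scatter) in this assay and so moved the number by more than the usual scatter, although the step is modest. The same change therefore did not carry over unchanged from the amide core of compound 1 to the ester core of compound 3: the same change on two cores in this assay, a 1.1-fold lower number (0.06 log units; within the scatter) from compound 1 to compound 2 and a 2.7-fold higher number (0.42 log units; beyond the scatter) from compound 3 to compound 4, 3.0-fold (0.48 log units) apart, beyond the scatter of two such steps. This rests on a single pair of compounds for each core, so it shows that the step can depend on the core, but it does not show why, nor whether the gap between the two cores would hold at other chain lengths.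

From the compounds shown here alone, it remains open whether a longer chain on the ester core would push the number further in the same direction, and whether the amide core would then begin to respond as well. Also open, going by these compounds, is how either core would behave if the end of the chain carried a polar group such as an amine or a carboxylic acid.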